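Compound 4: replacing the dimethylcarbamoyl group of compound 3

The compounds below may be only part of what the source reports. "The series", "measured", "known", "first", "only" and "open" are said of these compounds alone.

Measured so far in a toxicity assay on NIH3T3 cells (Mus musculus) for cytotoxicity, read by resazurin assay (a higher number here means that more compound is needed for the effect, a lower number that less compound is needed), each value being a limit:
- compound 1 `c1ccc(-c2ccc(Cn3cncc3CNc3ccc(-c4nc5ccccc5s4)c(-c4ccccc4)c3)cc2)cc1`: > 1000 nM
- compound 2 `c1ccc(-c2ccc(Cn3cncc3CNc3ccc(N4CCCCC4)c(-c4ccccc4)c3)cc2)cc1`: > 1000 nM
- compound 3 `CN(C)C(=O)c1ccc(NCc2cncn2Cc2ccc(-c3ccccc3)cc2)cc1-c1ccccc1`: > 1000 nM

Compound 3 gives no number in this assay, only the limit > 1000 nM. All the measured compounds stand together at the limit of > 1000 nM in this assay, at which 3 of the 3 values shown sit. Compound 4 `c1ccc(-c2ccc(Cn3cncc3CNc3ccc(-c4noc5ccccc45)c(-c4ccccc4)c3)cc2)cc1` has not been measured. It differs from compound 3 in one group on an aromatic carbon, ortho to a phenyl group and para to a large group: a group of 9 heavy atoms (7 carbon, 1 nitrogen, 1 oxygen; one five-membered aromatic ring with 2 hetero atoms, one six-membered aromatic ring of carbon only) in place of a group of 5 heavy atoms (3 carbon, 1 nitrogen, 1 oxygen; no ring), on an aromatic carbon.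

The measured steps that bear on this change are a step that the two limits leave unreadable from compound 1 to compound 3, a step that the two limits leave unreadable from compound 2 to compound 3 and a step that the two limits leave unreadable from compound 1 to compound 2. Each swaps the group at this same place, and none has a readable size. Going by the values given here, still, no compound among the three left the limit, so compound 4 is expected to report a limit too. The expected step is a step that the limit leaves unreadable from compound 3 to compound 4, with no direction beyond the scatter. For compound 4 the estimate is 2000 nM, with an expected range of 800 nM to 10000 nM.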

Compound 4, half-maximal effective concentration: > 10000 nM
Compound 4 gave a limit, no number; the forecaster's own chance of this, stated with the estimate: 85%; middle value at least 5.0-fold (0.69 log units) from the limit.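

In this assay compound 4 gives only a limit, > 10000 nM. Going by these compounds alone, compound 1, compound 2 and compound 3 also stand at limits, so no step from any of them to compound 4 can be read. The compounds shown leave open what concentration of any of them produces the effect.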